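Series notes: replacing the ether side chain with chloro

The source may hold more compounds than are shown below. What is called first, only, known or untested is meant among the compounds shown, and "the series" means these compounds.

Two compounds of the series carry numbers in an assay for inhibition of kynurenine 3-monooxygenase (Homo sapiens), read by mass spectrometry, with a stated time of 1 h; on this read-out lower numbers stand for stronger inhibition and higher numbers for weaker inhibition. Compound 1 `O=C(O)CCn1c(=O)oc2cc(OCC3CC3)c(Cl)cc21` gives 10 nM. Compound 2 `COCCOc1cc2oc(=O)n(CCC(=O)O)c2cc1Cl` gives 31.6 nM. Going by the values given here, the single measured step, a 3.2-fold higher number from compound 1 to compound 2 (0.50 log units; beyond the scatter), is a modest move beyond the scatter. Among the compounds with values here, compound 2 therefore stands highest of the two numbers, with compound 1 as its only neighbour, beyond the scatter.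

Compound 3 `O=C(O)CCn1c(=O)oc2cc(Cl)c(Cl)cc21` is not yet measured in this assay. Against compound 2 the change is chloro in place of 2-methoxyethoxy on an aromatic carbon. Within the data shown here, no measured step covers a chloro group entering at this position; the only step available, a 3.2-fold higher number from compound 1 to compound 2 (0.50 log units; beyond the scatter), concerns a change within the side chain that now leaves, and it shows that what sits on this oxygen moves the number beyond the scatter. Removing the chain altogether is a larger change than that step covers, so the direction is open, with a lower number somewhat more likely given that compound 1 with its smaller chain terminus already sits at 10 nM. Compound 3 is expected near 15 nM, in the range 4 nM to 60 nM. The expected step is a 2.1-fold lower number from compound 2 to compound 3 (0.32 log units; beyond the scatter).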

Compound 3, half-maximal inhibitory concentration in the kynurenine 3-monooxygenase assay: 6.31 nM
Compound 3: middle estimate off by 2.4-fold (0.38 log units), on the high side, within the range that was stated.
By their numbers in the kynurenine 3-monooxygenase assay, from the lowest: compounds 3 and 1 (each within the scatter of the next); then compound 2.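

In the kynurenine 3-monooxygenase assay, a 5.0-fold lower number from compound 2 to compound 3 (0.70 log units; beyond the scatter), and a 1.6-fold lower number from compound 1 to compound 3 (0.20 log units; within the scatter), so an oxygen-linked chain on this aromatic carbon is not needed for a number in this range, and chloro and cyclopropylmethoxy cannot be told apart here. In a physicochemical assay for permeability, using PAMPA (a higher number here means that the compound crosses the layer faster, a lower number that the compound crosses the layer more slowly), compound 2 gives < 3 nm/s, which is a limit of the assay and not a number: the limit of < 3 nm/s in the physicochemical assay, at which 1 of the 2 values shown sits. In the physicochemical assay compound 3 gives 24 nm/s. Going by these compounds alone, in the physicochemical assay the same exchange of 2-methoxyethoxy for chloro also comes with an at least 8.0-fold higher number from compound 2 to compound 3 (0.90 log units; beyond the scatter), the first view of this change on a second read-out.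

Open, as far as these compounds go, is whether a single atom or small group other than chloro, such as fluoro or methyl, or a chain ending in an amine, keeps the number in the kynurenine 3-monooxygenase assay in this range on this aromatic carbon, and how such groups read in the physicochemical assay. Also open, from the compounds shown here alone, is whether a tetrazole in place of the carboxylic acid would shift both read-outs on the core of compound 3.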